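Methyl Added to a Series Sitting Wholly at the Limit

The source may hold more compounds than are shown below. What is called first, only, known or untested is meant among the compounds shown, and "the series" means these compounds.

Compound 3 `CC(C)C[C@H](NC(=O)CNC(=O)c1ccn(CC(=O)NOCc2ccccc2)c1)C(=O)O` was examined in a functional assay on MRC5 cells (Homo sapiens) for inhibition, read by microscopy and resazurin assay, with a stated time of 72 h; a higher number here means a weaker inhibitor, a lower number a stronger inhibitor. In this assay compound 3 gives > 128000 nM, which is a limit of the assay and not a measured number. Its two neighbours stand the same way. Compound 1 `C=CCONC(=O)Cn1ccc(C(=O)NCC(=O)N[C@@H](CC(C)C)C(=O)O)c1` gives > 128000 nM in this assay, again a limit. Compound 2 `C=CCONC(=O)Cn1ccc(C(=O)N[C@@H](C)C(=O)N[C@@H](CC(C)C)C(=O)O)c1` gives > 128000 nM in this assay, once more a limit. The whole picture is summed up by the limit of > 128000 nM in this assay, at which 3 of the 3 values shown sit.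

Compound 4 `CC(C)C[C@H](NC(=O)[C@H](C)NC(=O)c1ccn(CC(=O)NOCc2ccccc2)c1)C(=O)O` differs from compound 3 in one place: methyl in place of hydrogen on a saturated chain carbon bound to an amide-type nitrogen and a carbonyl carbon. The same change has been made once before, and that step, a step that the two limits leave unreadable from compound 1 to compound 2, is of a size no one can read. The other measured step, a step that the two limits leave unreadable from compound 1 to compound 3, is equally unreadable, as both its ends are limits. Nothing here points in any direction.

Compound 4 is therefore expected to remain at the limit, with an estimate of 200000 nM and a range from 128000 nM to 1000000 nM. The step that the limit leaves unreadable from compound 3 to compound 4 is accordingly expected to be no more than an unreadable one, the new value likely a limit.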

Compound 4, half-maximal inhibitory concentration: > 128000 nM
Compound 4 ended at the assay's limit (the forecaster's own chance of this, stated with the estimate: 90%); the middle value does not contradict the limit.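

In this assay compound 4 gives > 128000 nM as a limit of the assay, so neither its step from compound 3 nor its step from compound 2 can be read. The compounds shown leave open whether the methyl or the phenyl change alters inhibition at all: the limit of > 128000 nM in this assay, at which 4 of the 4 values shown sit.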